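Trading the Aminooxy Chain for a Carbamoyl Group

The source may report more compounds than this note shows. Statements on the series, on what has been measured and on what is new or still open speak of the compounds shown alone.

Three nucleoside analogues have been tested so far in an assay on isolated protein for inhibition of S-adenosylmethionine decarboxylase proenzyme (Homo sapiens); on this read-out lower numbers stand for stronger inhibition and higher numbers for weaker inhibition. Compound 1 `Cc1nc2c(N)ncnc2n1[C@@H]1O[C@H](CN(C)CCN)[C@@H](O)[C@H]1O` gives 88000 nM, compound 3 `CNc1nc2c(N)ncnc2n1[C@@H]1O[C@H](CN(C)CCCN)[C@@H](O)[C@H]1O` gives 440000 nM, and compound 2 `CN(CCCCON)C[C@H]1O[C@@H](n2cnc3c(N)ncnc32)[C@H](O)[C@@H]1O` gives 18 nM, the lowest of the three numbers and therefore the strongest inhibition among them, with gaps to compound 1 and to compound 3 that lie far beyond the scatter.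

Compound 4 `CN(CCC(N)=O)C[C@H]1O[C@@H](n2cnc3c(N)ncnc32)[C@H](O)[C@@H]1O` has not yet been measured in this assay. It differs from compound 2 in a single place: carbamoyl in place of 2-(aminooxy)ethyl on a saturated chain carbon, two bonds along the chain from an amine nitrogen. Among the measured compounds shown here, no measured pair shows this exact change, so its effect can only be anticipated from the wider picture. The two measured compounds that lack an aminooxy group are both weak: compound 1 gives 88000 nM and compound 3 gives 440000 nM. On that basis compound 4, which also lacks the aminooxy group, is expected to fall well short of compound 2. The expected step from compound 2 to compound 4 is a large rise, a 5600-fold higher number from compound 2 to compound 4 (3.74 log units; beyond the scatter). Compound 4 is estimated at 100000 nM, with a likely range from 10000 nM to 1000000 nM.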

Compound 4, half-maximal inhibitory concentration: 7000 nM
The estimate for compound 4 lay 14-fold (1.15 log units) above the measured number, and the stated range ends above it.
By their numbers in this assay, from the lowest: compound 2; then compound 4; then compound 1; then compound 3.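

In this assay, among the compounds shown here, replacing 2-(aminooxy)ethyl with carbamoyl at this place on the chain gives a 390-fold higher number from compound 2 to compound 4 (2.59 log units; beyond the scatter), the first direct reading of a change in which everything else in the molecule stays the same. The step lies beyond the usual scatter, so inhibition is highly sensitive to what sits at this place, and the aminooxy-bearing chain of compound 2 is far better here than the carbamoyl-bearing chain of compound 4. No measurement shown here accounts for the size of this step.

The same change can also be read as 4-(aminooxy)butyl to 2-carbamoylethyl, so the compounds shown leave open how much of the step comes from the end group and how much from the chain length. Keeping the rest of the molecule fixed, a 4-aminobutyl chain would test the end group at the longer length, and a 3-(aminooxy)propyl chain would test the aminooxy group at a shorter one.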